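The source may report more compounds than this note shows. Statements on the series, on what has been measured and on what is new or still open speak of the compounds shown alone.

Among the measured compounds shown here, compound 2 `COc1ccc(-c2csc(N3N=C(c4ccc(Cl)cc4)CC3c3cccs3)n2)cc1` gives 1310 nM in a functional assay on WM 266-4 cells (Homo sapiens) for antiproliferative activity, read by MTT assay, with a stated time of 48 h (a lower number here means a stronger inhibitor, a higher number a weaker inhibitor), the lower of the two numbers so far, though compound 1 `Clc1ccc(C2=NN(c3nc(-c4ccccc4)cs3)C(c3cccs3)C2)cc1` with 2190 nM lies within the scatter of it, the step being a 1.7-fold lower number from compound 1 to compound 2 (0.22 log units; within the scatter). Compound 3 `FC(F)(F)c1ccc(-c2csc(N3N=C(c4ccc(Cl)cc4)CC3c3cccs3)n2)cc1` differs from compound 2 by trifluoromethyl in place of methoxy on an aromatic carbon. For the measured compounds named here, only that single step, methoxy in place of hydrogen, bears on this position, and it stayed within the scatter; nothing measured speaks to trifluoromethyl in place of methoxy. The estimated step of a 1.1-fold higher number from compound 2 to compound 3 (0.06 log units; within the scatter) is therefore expected to stay within the scatter. Compound 3 is estimated at 1500 nM, in the range 600 nM to 4000 nM.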

Compound 3, half-maximal inhibitory concentration: 120 nM
Beside the measured number, compound 3's estimate is 13-fold (1.10 log units) above it; measured number below the stated range.
By their numbers in this assay, from the lowest: compound 3; then compounds 2 and 1 (each within the scatter of the next).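

In this assay this position proves able to move the number far, which the earlier step within the scatter had not shown: trifluoromethyl gives an 11-fold lower number from compound 2 to compound 3 (1.04 log units; beyond the scatter), and against hydrogen it gives an 18-fold lower number from compound 1 to compound 3 (1.26 log units; beyond the scatter). The outcome thus depends on which group enters here, with methoxy and hydrogen within the scatter of each other and trifluoromethyl clear of both. Nothing available here accounts for this difference. Going by these compounds, how a chlorine atom, a nitrile or an amine at this position would compare remains open, as does whether the change carries over to other groups on the shared core.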